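The compounds below may be only part of what the source reports. "The series", "measured", "known", "first", "only" and "open" are said of these compounds alone.

Compound 2 `COc1ccc(-n2ccnc2SCC(=O)Nc2ccccc2F)cc1` stands in an ADME assay on MT4 cells (Homo sapiens) for cytotoxicity, read by MTT assay (a lower number here means that less compound is tolerated, a higher number that more compound is tolerated), at >= 41900 nM, which is a limit of the assay rather than a number. Its neighbour compound 1 `O=C(CSc1nccn1-c1ccc(Cl)cc1)Nc1ccccc1F` gives in this assay > 345000 nM, again a limit. The step that the two limits leave unreadable from compound 1 to compound 2 therefore cannot be sized: as the limit of > 345000 nM in this assay, at which 1 of the 2 values shown sits, and the limit of >= 41900 nM in this assay, at which 1 of the 2 values shown sits, show, both values sit at limits, and no readable step exists among the measured compounds.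

Compound 3 `Cc1ccc(-n2ccnc2SCC(=O)Nc2ccccc2F)cc1` differs from compound 2 by methyl in place of methoxy on an aromatic carbon, para to a large group. Going by the values given here, with no measured step to lean on, no change beyond the scatter is expected from compound 2 to compound 3, and the step that the limit leaves unreadable from compound 2 to compound 3 is estimated as negligible. Compound 3 is accordingly expected to give about 120000 nM in this assay, within a range from 40000 nM to 400000 nM, most likely again reported only as a limit.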

Compound 3, half-maximal cytotoxic concentration: 37900 nM
For compound 3 the middle estimate is 3.2-fold (0.50 log units) above the measured one, outside the stated range (below it).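

Of the three compounds, compound 3 alone gives a number rather than a limit in this assay, so this position now has a first firm anchor. Methyl in place of chloro gives an at least 9.1-fold lower number from compound 1 to compound 3 (0.95 log units; beyond the scatter), the first step at this position that clears the scatter. Methyl in place of methoxy gives only an at least 1.1-fold lower number from compound 2 to compound 3 (0.04 log units; that floor lies within the scatter), and this floor is all that can be read because compound 2 stands at a limit: the limit of >= 41900 nM in this assay, at which 1 of the 3 values shown sits.

From the compounds shown here alone, the true size of the step from 4-methoxyphenyl to 4-methylphenyl remains open, so it is unclear whether methoxy and methyl differ at all here. Also open, going by these compounds, is how the number would respond to an amine, a carboxylic acid or a longer chain on this aromatic carbon.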